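From 4-fluoro-3-methylbenzyl to benzyl

The source may hold more compounds than are shown below. What is called first, only, known or untested is meant among the compounds shown, and "the series" means these compounds.

Measured in an in vivo ADME assay on the whole organism for pharmacokinetics, with Rattus norvegicus as the target, at a dose of 2 mg/kg by the intravenous route; on this read-out lower numbers stand for slow clearance and higher numbers for fast clearance:
Compound 1 `CC(C)(C)[C@H]1C(O)=C(C2=CS(=O)(=O)c3cc(NS(C)(=O)=O)ccc3N2)C(=O)N1Cc1ccc(F)cc1` gives 101 mL/min/kg
Compound 2 `Cc1cc(CN2C(=O)C(C3=CS(=O)(=O)c4cc(NS(C)(=O)=O)ccc4N3)=C(O)[C@@H]2C(C)(C)C)ccc1F` gives 101 mL/min/kg

For the measured compounds named here, compound 2 stands level with compound 1, the only other measured compound. Compound 3 `CC(C)(C)[C@H]1C(O)=C(C2=CS(=O)(=O)c3cc(NS(C)(=O)=O)ccc3N2)C(=O)N1Cc1ccccc1` differs from compound 2 by one change: phenyl in place of 4-fluoro-3-methylphenyl on a saturated chain carbon bound to an amide-type nitrogen in a ring. That is phenyl in place of 4-fluoro-3-methylphenyl on a saturated chain carbon bound to an amide-type nitrogen in a ring. Going by the values given here, one measured step bears on this, methyl in place of hydrogen on an aromatic carbon: no change at the digits printed from compound 1 to compound 2 (within the scatter). Among the compounds with values here, it covers the methyl group only, and no measured step isolates the fluorine. No shift beyond the scatter is expected in this assay, and the expected step is a 1.1-fold lower number from compound 2 to compound 3 (0.05 log units; within the scatter). Compound 3 is estimated at 90 mL/min/kg (range 50 mL/min/kg to 160 mL/min/kg).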

Compound 3, clearance: 144 mL/min/kg
Estimate against measurement, compound 3: 1.6-fold (0.20 log units) below; low and high end bracket the measured number.
By their numbers in this assay, from the lowest: compounds 1, 2 and 3 (each within the scatter of the next).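

In this assay, for the compounds shown here, phenyl in place of 4-fluoro-3-methylphenyl gives a 1.4-fold higher number from compound 2 to compound 3 (0.15 log units; within the scatter) for the full exchange, and hydrogen in place of fluoro gives a 1.4-fold higher number from compound 1 to compound 3 (0.15 log units; within the scatter) for the fluorine alone, a step the earlier compounds did not isolate. Thus neither the whole exchange nor the fluorine by itself moves the read-out beyond the scatter on this benzyl group. Nothing available here accounts for these numbers.

The compounds shown carry only hydrogen, fluoro and methyl on this ring. As far as these compounds go, whether an amine or a carboxylic acid on it would shift clearance beyond the scatter stays open.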